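Amide aryl swap at the cytotoxicity limit

This account rests on a few compounds, and the source may have more. Where it says the series, first, only, none or still open, it means among the compounds named here.

- compound 1 `Cc1ccc(S(=O)(=O)N[C@@H](CC(=O)NC(C)(C)C)C(=O)NCCNC(=O)c2cc(Cl)ccn2)cc1` gives > 11000 nM (a limit)
- compound 2 `Cc1ccc(S(=O)(=O)N[C@@H](CC(=O)NC(C)(C)C)C(=O)NCCNC(=O)c2cccc(C#N)c2)cc1` gives > 11000 nM (a limit)

In an ADME assay on HepG2 cells (Homo sapiens) for cytotoxicity (a lower number here means that less compound is needed, a higher number that more compound is needed for the effect), compound 2 stands at > 11000 nM as a limit of the assay and not a number. Both measured compounds share that limit (the limit of > 11000 nM in this assay, at which 2 of the 2 values shown sit). Compound 3 `Cc1ccc(S(=O)(=O)N[C@@H](CC(=O)NC(C)(C)C)C(=O)NCCNC(=O)c2cc(C)ccn2)cc1` differs from compound 2 at one place (4-methylpyridin-2-yl in place of 3-cyanophenyl on a carbonyl carbon), with 4-methylpyridin-2-yl in place of 3-cyanophenyl on a carbonyl carbon. For the measured compounds named here, the only measured step at that place is a step that the two limits leave unreadable from compound 1 to compound 2 and its size cannot be read. Going by the values given here, with that step as the only guide, no step beyond the scatter is expected in this assay in either direction. Compound 3 is expected at 12000 nM with an estimated range of 8000 nM to 25000 nM and most likely as a limit again. The expected change is a step that the limit leaves unreadable from compound 2 to compound 3 and lies within the scatter.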

Compound 3, half-maximal effective concentration: > 11000 nM
Compound 3: a limit, no number; the forecaster's own chance of this, stated with the estimate: 90%; the middle value does not contradict the limit.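

No step can be read among compound 1, compound 2 and compound 3 in this assay, since each value is a limit and not a number: the limit of > 11000 nM in this assay, at which 3 of the 3 values shown sit.

Still open, as far as these compounds go, is how these compounds order in this assay, and whether any group on the carbonyl carbon would give a measurable value.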